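Amide to urea on the aryl side chain

A few compounds are considered here, and "the series" means these few. Any claim that something is new, unique, unknown or untested is made for them only; others in the source may bear on it.

Three compounds share a core built from compound 1 `COc1cc(-c2cncc(N[C@@H](C)c3ccccc3)n2)ccc1O`, and all were tested in a functional assay on PC-3 cells (Homo sapiens) for cytotoxicity, read by MTT assay, with a stated time of 72 h; on this read-out lower numbers stand for stronger inhibition and higher numbers for weaker inhibition. Compound 1 gives 10000 nM. Compound 2 `CCCC(Nc1cncc(-c2ccc(O)c(OC)c2)n1)c1cccnc1` gives 300 nM. Compound 3 `CCCC(=O)Nc1ccc(-c2cncc(NC(CCC)c3cccnc3)n2)cc1OC` gives 600 nM, the second highest of the three numbers; its nearest neighbour is compound 2, and the step of a 2.0-fold higher number from compound 2 to compound 3 (0.30 log units; within the scatter) lies within the usual scatter, while compound 1 sits far above it.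

Compound 4 `CCCC(Nc1cncc(-c2ccc(NC(=O)NCC)c(OC)c2)n1)c1cccnc1` has not been measured. It differs from compound 3 in one place: ethylamino in place of propyl on a carbonyl carbon, so that the (propylcarbonyl)amino group becomes an (ethylcarbamoyl)amino group.

Going by the values given here, no measured pair shows this change. Among the compounds with values here, the only single step available, a 2.0-fold higher number from compound 2 to compound 3 (0.30 log units; within the scatter), concerns the hydroxy-to-amide exchange on the same aromatic carbon and was small. That does not bear directly on swapping propyl for ethylamino on the carbonyl carbon, so there is no basis to expect a shift beyond the scatter in either direction.

Compound 4 is therefore estimated at 600 nM, in a range from 250 nM to 1500 nM. The expected step of no change at the digits printed from compound 3 to compound 4 (within the scatter) is thus essentially flat.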

Compound 4, half-maximal inhibitory concentration: 40 nM
Compound 4: the middle estimate sits 15-fold (1.18 log units) above what was measured; measured number outside the range, below it.
By their numbers in this assay, from the lowest: compound 4; then compounds 2 and 3 (each within the scatter of the next); then compound 1.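

In this assay, going by these compounds alone, the group on this carbonyl carbon matters far more than the earlier compounds suggested: a 15-fold lower number from compound 3 to compound 4 (1.18 log units; beyond the scatter) comes from replacing propyl with ethylamino, a swap in which three heavy atoms leave and three enter, but one carbon becomes a nitrogen and a hydrogen-bond donor is added. The earlier exchange of hydroxy for (propylcarbonyl)amino on the aromatic carbon stayed within the scatter, at a 2.0-fold higher number from compound 2 to compound 3 (0.30 log units; within the scatter), whereas (ethylcarbamoyl)amino in the same place gives a 7.5-fold lower number from compound 2 to compound 4 (0.88 log units; beyond the scatter), so this aromatic carbon is not indifferent to what it carries. No measurement here explains why this single change has so large an effect.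

Going by these compounds, this is one pair, so it sets no general rule, and it remains open whether the stronger inhibition depends on the ethyl group or would persist with methylamino, a longer chain such as butylamino, or ethoxy on the same carbonyl carbon. On these data alone, it is also open whether the (ethylcarbamoyl)amino group would have a similar effect with a different group on the amine of the shared core, such as the 1-phenylethyl group of compound 1.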